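The compounds below may be only part of what the source reports. "The series", "measured", "known", "first", "only" and "open" are said of these compounds alone.

Working notes on the series, all read in a functional assay on HepG2 cells (Homo sapiens) for inhibition, read by MTT assay; on this read-out lower numbers stand for stronger inhibition and higher numbers for weaker inhibition. Compound 1 `COc1cc2ncnc(Nc3ccc(NC(=O)c4ccccc4C)cc3)c2cc1OC` gives 15000 nM, and compound 2 `CCc1ccc(C(=O)Nc2ccc(Nc3ncnc4cc(OC)c(OC)cc34)cc2)cc1` gives 72000 nM. Compound 3 `COc1cc2ncnc(Nc3ccc(NC(=O)c4ccc(C(C)(C)C)cc4)cc3)c2cc1OC` gives > 100000 nM, which is a limit of the assay and not a number.

The next change is from compound 3 to compound 4 `COc1cc2ncnc(Nc3ccc(NC(=O)c4cccc(F)c4)cc3)c2cc1OC`: 3-fluorophenyl in place of 4-(tert-butyl)phenyl on a carbonyl carbon. Here 3-fluorophenyl replaces 4-(tert-butyl)phenyl on a carbonyl carbon.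

Among the measured compounds shown here, three measured steps concern this same place. They are a 4.8-fold higher number from compound 1 to compound 2 (0.68 log units; beyond the scatter), an at least 6.6-fold higher number from compound 1 to compound 3 (0.82 log units; beyond the scatter) and an at least 1.3-fold higher number from compound 2 to compound 3 (0.14 log units; that floor lies within the scatter), the last with a floor within the scatter. For the measured compounds named here, no measured compound yet carries 3-fluorophenyl, so the aryl groups with real numbers set the working span. That span runs from compound 1 at 15000 nM to compound 2 at 72000 nM, and compound 4 is expected to fall inside it.

The expected change is an at least 2.8-fold lower number from compound 3 to compound 4 (0.45 log units; beyond the scatter), a modest step towards a lower number, similar in size to an at least 6.6-fold higher number from compound 1 to compound 3 (0.82 log units; beyond the scatter). The estimate for compound 4 is 35000 nM, with an expected range of 12000 nM to 100000 nM.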

Compound 4, half-maximal inhibitory concentration: 8200 nM
Beside the measured number, compound 4's estimate is 4.3-fold (0.63 log units) above it; the measured number lies below the stated range.
By their numbers in this assay, from the lowest: compounds 4 and 1 (each within the scatter of the next); then compound 2. At a limit, above all of these: compound 3.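

In this assay, a low number on this carbonyl carbon is no longer tied to 2-methylphenyl: 3-fluorophenyl gives an 8.8-fold lower number from compound 2 to compound 4 (0.94 log units; beyond the scatter), while a 1.8-fold lower number from compound 1 to compound 4 (0.26 log units; within the scatter) leaves compounds 1 and 4 together at the low end. Both compounds carrying a 4-alkylphenyl group now read higher than these two, and the change away from 4-(tert-butyl)phenyl gives an at least 12-fold lower number from compound 3 to compound 4 (1.08 log units; beyond the scatter), a step whose size is only a floor. Compound 3 holds a limit and not a number: the limit of > 100000 nM in this assay, at which 1 of the 4 values shown sits.

The compounds shown leave open whether the low numbers follow the place of the substituent on the ring or its kind, which a 4-fluorophenyl or 3-methylphenyl group on this carbonyl carbon would help separate. On these data alone, how an amine or a carboxylic acid on this ring would read also stays open.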